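The source may hold more compounds than are shown below. What is called first, only, known or untested is meant among the compounds shown, and "the series" means these compounds.

Compound 1, `OC[C@H]1O[C@@H](n2cnc3c(NCc4ccccc4F)ncnc32)[C@H](O)[C@@H]1O`, compound 2, `OC[C@H]1O[C@@H](n2cnc3c(NCc4cccc(F)c4)ncnc32)[C@H](O)[C@@H]1O`, and compound 3, `OC[C@H]1O[C@@H](n2cnc3c(NCc4ccc(F)cc4)ncnc32)[C@H](O)[C@@H]1O`, share one core and differ only in where the fluorine sits on the benzyl group. In a functional assay on B16 cells (Mus musculus) for antiproliferative activity, with a stated time of 72 h (a lower number here means a stronger inhibitor, a higher number a weaker inhibitor), compound 1 gives > 166000 nM, which is a limit of the assay and not a number. For compound 2 the record in this assay reads "not determined" (no result reported), and for compound 3 it likewise reads "not determined" (no result reported), so compound 2 stands without a single number of its own. Among the three entries, one is a limit and two have no result at all. The only anchor is the limit of > 166000 nM in this assay, at which 1 of the 3 values shown sits.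

Compound 4, `OC[C@H]1O[C@@H](n2cnc3c(NCc4ccc(F)cc4F)ncnc32)[C@H](O)[C@@H]1O`, is not yet measured. It differs from compound 2 by 2,4-difluorophenyl in place of 3-fluorophenyl on a saturated chain carbon bound to a nitrogen on an aromatic ring. For the measured compounds named here, with no measured step to lean on, no change beyond the usual scatter is expected in this assay in either direction, and the limit seen for compound 1 points toward weak inhibition throughout this small set. Compound 4 is therefore expected to give about 150000 nM, within a range from 30000 nM to 500000 nM, with a fair chance that only a limit is reported.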

Compound 4, half-maximal inhibitory concentration: > 166000 nM
Compound 4: no number, only a limit; the forecaster's own chance of this, stated with the estimate: 65%; middle value at least 1.1-fold (0.04 log units) away from the limit.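

Compound 4 gives > 166000 nM in this assay, which is a limit of the assay and not a number. No step can be read from compound 1 to compound 4, because both rest on the same limit: the limit of > 166000 nM in this assay, at which 2 of the 4 values shown sit.

The compounds shown leave open whether any fluorine placement on the benzyl group yields a single number in this assay.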